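This account rests on a few compounds, and the source may have more. Where it says the series, first, only, none or still open, it means among the compounds named here.

Among the compounds with values here, compound 2, `CCCCCCCCS(=O)(=O)Nc1ccc(-c2ccccc2Cl)cc1C(=O)O`, is one of two compounds so far examined in an assay on mitochondria (strain BALB/c) for inhibition of glycerol-3-phosphate acyltransferase 1, mitochondrial (Mus musculus), read by scintillation counting, with a stated time of 10 min (on this read-out lower numbers stand for stronger inhibition and higher numbers for weaker inhibition), where compound 2 gives 14400 nM. Compound 1, `CCCCCCCCS(=O)(=O)Nc1cc(-c2ccccc2OC)ccc1C(=O)O`, gives 16100 nM in this assay, and the two numbers sit within the usual scatter of each other. Compound 3, `CCCCCCCCS(=O)(=O)Nc1ccc(-c2ccccc2F)cc1C(=O)O`, has not yet been measured. It differs from compound 2 by fluoro in place of chloro on an aromatic carbon. Within the data shown here, no measured pair shows what this exchange does here, so the expected step is a 1.3-fold higher number from compound 2 to compound 3 (0.10 log units; within the scatter), a small one that stays close to the scatter. Compound 3 is therefore estimated at 18000 nM in this assay, with a range from 8000 nM to 40000 nM.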

Compound 3, half-maximal inhibitory concentration: 34600 nM
For compound 3 the middle estimate is 1.9-fold (0.28 log units) below the measured one, within the range that was stated.
By their numbers in this assay, from the lowest: compounds 2 and 1 (each within the scatter of the next); then compound 3.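

Swapping chloro for fluoro on the 2-chlorophenyl group is not a neutral exchange in this assay (a 2.4-fold higher number from compound 2 to compound 3 (0.38 log units; beyond the scatter)). This single atom, ortho to a large group, therefore affects inhibition, and of these two groups, chloro gives the lower number. Nothing measured here explains the step.

As far as these compounds go, it remains open whether bromo or methyl at this place would give a lower number than chloro, or whether the same exchange would give a similar step with a shorter chain in place of the long one.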